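The source may report more compounds than this note shows. Statements on the series, on what has been measured and on what is new or still open speak of the compounds shown alone.

Series notes. The shared core carries an alkyne whose far end is varied. Compound 1 `O=c1[nH]c(=O)n(CCC(CO)CO)cc1C#Cc1cc(F)cc(F)c1` gives 63100 nM in a functional assay on MCF7 cells (Homo sapiens) for antiproliferative activity, read by MTT assay, with a stated time of 72 h; a higher number here means a weaker inhibitor, a lower number a stronger inhibitor. Compound 2 `O=c1[nH]c(=O)n(CCC(CO)CO)cc1C#Cc1ccc(Br)cc1` gives 46000 nM in this assay. Compound 3 `O=c1[nH]c(=O)n(CCC(CO)CO)cc1C#CC1CC1` gives > 100000 nM in this assay, which is a limit of the assay and not a number, the limit being (the limit of > 100000 nM in this assay, at which 1 of the 3 values shown sits). The steps from an aryl group to cyclopropyl ran an at least 1.5-fold higher number from compound 1 to compound 3 (0.19 log units; that floor lies within the scatter) and an at least 2.1-fold higher number from compound 2 to compound 3 (0.33 log units; beyond the scatter), while the aryl swap itself was a 1.4-fold lower number from compound 1 to compound 2 (0.14 log units; within the scatter). Compound 4 `CCCCCC#Cc1cn(CCC(CO)CO)c(=O)[nH]c1=O` is not yet measured; it differs from compound 3 by pentyl in place of cyclopropyl on a triple-bonded carbon. For the measured compounds named here, only the steps into compound 3 bear on it, and none of them reaches past the limit. Compound 4 is therefore expected near the limit, at an estimated 110000 nM (range 50000 nM to 300000 nM) in this assay. The expected step is a step that the limit leaves unreadable from compound 3 to compound 4, none beyond the scatter.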

Compound 4, half-maximal inhibitory concentration: 37800 nM
Beside the measured number, compound 4's estimate is 2.9-fold (0.46 log units) above it, and the stated range ends above it.
By their numbers in this assay, from the lowest: compounds 4, 2 and 1 (each within the scatter of the next). At a limit, above all of these: compound 3.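

On the triple-bonded carbon, pentyl in place of cyclopropyl gives the first step out of the limit in this assay, an at least 2.6-fold lower number from compound 3 to compound 4 (0.42 log units; beyond the scatter). Compound 3 remains a limit and not a number, so that step is only a floor: the limit of > 100000 nM in this assay, at which 1 of the 4 values shown sits. Pentyl stands level with both aryl groups, with a 1.2-fold lower number from compound 2 to compound 4 (0.09 log units; within the scatter) and a 1.7-fold lower number from compound 1 to compound 4 (0.22 log units; within the scatter), so an aromatic ring on this carbon is not needed to reach that level.

As far as these compounds go, whether a chain longer than pentyl changes the number remains open. So does the effect of a chain ending in an amine or a carboxylic acid at this carbon.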